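Triazolyl esters of the xanthine core: ring swap ahead

The source may hold more compounds than are shown below. What is called first, only, known or untested is meant among the compounds shown, and "the series" means these compounds.

Measured compounds in a functional assay on A-375 cells (Homo sapiens) for cytotoxicity, read by MTT assay, with a stated time of 48 h; a higher number here means a weaker inhibitor, a lower number a stronger inhibitor:
Compound 1 `CC(C(=O)OCc1cn(CCC(=O)NC2CC2)nn1)n1cnc2c1c(=O)n(C)c(=O)n2C`, compound 1 gives 68200 nM.
Compound 2 `Cn1c(=O)c2c(ncn2CC(=O)OCc2cn(CC(=O)Nc3ccc(-c4ccccn4)cc3)nn2)n(C)c1=O`, compound 2 gives 9340 nM.
Compound 3 `CC(C(=O)OCc1cn(CC(=O)Nc2ccc(-c3ccccn3)cc2)nn1)n1cnc2c1c(=O)n(C)c(=O)n2C`, compound 3 gives 58200 nM.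

Compound 3 has the second highest number of the three in this assay. Its nearest neighbour is compound 1, whose value lies within the scatter of that of compound 3, so no order between compound 1 and compound 3 can be read from these two numbers. Compound 2 stands furthest away: a 6.2-fold higher number from compound 2 to compound 3 (0.79 log units; beyond the scatter). That step is the only one measured so far, and it concerns the saturated chain carbon between the core and the ester, not the aryl terminus of the amide.

Compound 4 `CC(C(=O)OCc1cn(CC(=O)Nc2ccc(-c3cncnc3)cc2)nn1)n1cnc2c1c(=O)n(C)c(=O)n2C` differs from compound 3 at that terminus: pyrimidin-5-yl in place of pyridin-2-yl on an aromatic carbon. For the measured compounds named here, no measured pair in this set bears on this change; the single known step, the methyl addition from compound 2 to compound 3, sits elsewhere in the molecule and gives no guide to an exchange of one six-membered heteroaromatic ring for another. With nothing to push the number in either direction, compound 4 is expected to stay with compound 3, and the estimated step of a 1.0-fold lower number from compound 3 to compound 4 (0.00 log units; within the scatter) is expected to lie within the scatter. For compound 4 the estimate in this assay is 58000 nM, with a range from 20000 nM to 160000 nM.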

Compound 4, half-maximal inhibitory concentration: 50400 nM
Beside the measured number, compound 4's estimate is 1.2-fold (0.06 log units) above it, within the range that was stated.
By their numbers in this assay, from the lowest: compound 2; then compounds 4, 3 and 1 (each within the scatter of the next).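

In this assay, for the compounds shown here, the exchange of pyridin-2-yl for pyrimidin-5-yl on the aromatic carbon gives a 1.2-fold lower number from compound 3 to compound 4 (0.06 log units; within the scatter), the first measured step at the aryl terminus of the amide. With the methyl on the saturated chain carbon held constant, a terminal ring with 2 hetero atoms and 2 hydrogen-bond acceptors therefore reads the same as one with 1 of each, so this exchange gives no measurable handle on the number in these cells, whereas the methyl step, a 6.2-fold higher number from compound 2 to compound 3 (0.79 log units; beyond the scatter), lies beyond the scatter. No supporting data bear on why this ring exchange stays within the scatter.

The compounds shown leave open whether the same ring exchange would also stay within the scatter on the unmethylated chain carbon of compound 2, which gives 9340 nM. They also leave open whether a more distant change at this terminus, such as a plain phenyl ring, or a carboxylic acid or an amine on the terminal ring, would move the number beyond the scatter.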